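The source may hold more compounds than are shown below. What is called first, only, known or untested is meant among the compounds shown, and "the series" means these compounds.

Measured so far in a functional assay on DU-145 cells (Homo sapiens) for cytotoxicity, read by sulforhodamine B assay, with a stated time of 48 h; a higher number here means a weaker inhibitor, a lower number a stronger inhibitor:
- compound 1 `COc1ccc(/C=C2\C(=O)N(Cc3cn([C@@H]4O[C@H](COC(C)=O)[C@@H](OC(C)=O)[C@H](OC(C)=O)[C@H]4OC(C)=O)nn3)c3ccccc32)cc1OC` gives 24900 nM
- compound 2 `CC(=O)OC[C@H]1O[C@@H](n2cc(CN3C(=O)/C(=C\C=C\c4ccccc4)c4ccccc43)nn2)[C@H](OC(C)=O)[C@@H](OC(C)=O)[C@@H]1OC(C)=O` gives 19500 nM

For the measured compounds named here, compound 2 holds the lowest of the two numbers, with compound 1 nearest; the only measured step is a 1.3-fold lower number from compound 1 to compound 2 (0.11 log units; within the scatter), so the two compounds cannot be set apart on this assay.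

Compound 3 `CC(=O)OC[C@H]1O[C@@H](n2cc(CN3C(=O)/C(=C\c4ccc(N(C)C)cc4)c4ccccc43)nn2)[C@H](OC(C)=O)[C@@H](OC(C)=O)[C@@H]1OC(C)=O` differs from compound 2 by 4-(dimethylamino)phenyl in place of 2-phenylethenyl on a double-bonded chain carbon bound to a double-bonded ring carbon. Going by the values given here, the one measured step bearing on this change, a 1.3-fold lower number from compound 1 to compound 2 (0.11 log units; within the scatter), also exchanged the group at the same place and stayed within the scatter. With no further data on this position, the expectation for compound 3 is no change beyond the scatter, a step of a 1.1-fold lower number from compound 2 to compound 3 (0.03 log units; within the scatter). Among the compounds with values here, compound 3 is therefore estimated at 18000 nM, with a range from 7000 nM to 45000 nM; the range is kept wide since only one step supports the estimate.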

Compound 3, half-maximal inhibitory concentration: 10100 nM
Estimate against measurement, compound 3: 1.8-fold (0.25 log units) above; measured number inside the range.
By their numbers in this assay, from the lowest: compounds 3, 2 and 1 (each within the scatter of the next, the first and the last beyond it).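

In this assay this position now shows its first step beyond the scatter, though a modest one: a 2.5-fold lower number from compound 1 to compound 3 (0.39 log units; beyond the scatter), with 4-(dimethylamino)phenyl in place of 3,4-dimethoxyphenyl. The other exchange, 4-(dimethylamino)phenyl in place of 2-phenylethenyl, gives a 1.9-fold lower number from compound 2 to compound 3 (0.29 log units; within the scatter), so it does not set those two compounds apart. For the compounds shown here, the group on the double-bonded chain carbon can therefore shift the number, but only one of the three pairs shows this, and nothing available explains that difference.

The compounds shown leave open whether the nitrogen of the dimethylamino group is needed, which a carboxylic acid or a plain phenyl in the same place would help to test. They also leave open whether a longer amine chain on that phenyl ring would carry the step further.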